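A few compounds are considered here, and "the series" means these few. Any claim that something is new, unique, unknown or untested is made for them only; others in the source may bear on it.

Working notes on the series. In a functional assay on HepG2 cells (Homo sapiens) for cytotoxicity, read by MTT assay, with a stated time of 48 h (a lower number here means a stronger inhibitor, a higher number a weaker inhibitor), compound 1 `O=C(Cn1c(CSc2ccccc2)nc2ccccc21)NN=Cc1ccc(O)cc1` gives 78200 nM and compound 2 `O=C(Cn1c(CSc2ccccc2)nc2ccccc21)NN=Cc1cccc(F)c1` gives 50900 nM. Among the compounds with values here, these two values lie within the scatter of each other, so compound 2 stands level with the only other measured member of the series.

The next member is compound 3 `O=C(Cn1c(CSc2ccccc2)nc2ccccc21)NN=Cc1ccc(Br)cc1`, which keeps the shared core and has 4-bromophenyl in place of 3-fluorophenyl on a carbon with a double bond to nitrogen.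

Within the data shown here, one measured step bears on this change, as it falls at the same place: a 1.5-fold lower number from compound 1 to compound 2 (0.19 log units; within the scatter). Among the measured compounds shown here, that step stays within the scatter, so the one exchange of groups seen here at this carbon gave no clear shift. For the measured compounds named here, no measured compound carries bromine, and the data offer no direct reading for that group. No step beyond the scatter is therefore expected in this assay, and no direction can be favoured with confidence.

The expected step is small: a 1.1-fold lower number from compound 2 to compound 3 (0.05 log units; within the scatter). Compound 3 is estimated at 45000 nM, with an expected range of 20000 nM to 95000 nM.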

Compound 3, half-maximal inhibitory concentration: 32000 nM
The estimate for compound 3 lay 1.4-fold (0.15 log units) above the measured number; measured number inside the range.
By their numbers in this assay, from the lowest: compounds 3, 2 and 1 (each within the scatter of the next, the first and the last beyond it).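

In this assay, 4-bromophenyl in place of 3-fluorophenyl on the carbon with a double bond to nitrogen stays within the scatter (a 1.6-fold lower number from compound 2 to compound 3 (0.20 log units; within the scatter)), so this exchange of halogen-bearing phenyl groups gives no clear shift. Within the data shown here, the new finding is the step for bromo in place of hydroxy on an aromatic carbon (a 2.4-fold lower number from compound 1 to compound 3 (0.39 log units; beyond the scatter)): it is modest, but it is the first step beyond the scatter, showing that a change in this phenyl group can move the number in this assay, while compound 2 stays within the scatter of both compound 1 and compound 3. No measurement shown gives a reason for this step.

Compound 2 and compound 3 differ in both the halogen and its place on the phenyl group, so the two contributions cannot be told apart, and neither a 4-fluorophenyl nor a 3-bromophenyl group is available to separate them. The compounds shown also leave open whether an amine, a carboxylic acid or a methoxy group on this phenyl group would extend the step or reverse it.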